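The source may report more compounds than this note shows. Statements on the series, on what has been measured and on what is new or still open speak of the compounds shown alone.

In a functional assay on V79 cells (Cricetulus griseus) for cytotoxicity, read by colony formation (on this read-out lower numbers stand for stronger inhibition and higher numbers for weaker inhibition), compound 1 `COc1c(N2CCNCC2)c(F)cc2c(=O)c(C(=O)O)cn(C3CC3)c12` gives 82 ug/mL and compound 2 `O=C(O)c1cn(C2CC2)c2c(C(F)(F)F)c(N3CCNCC3)c(F)cc2c1=O` gives 1650 ug/mL, the higher of the two numbers. Compound 3 `CC1CN(c2c(F)cc3c(=O)c(C(=O)O)cn(C4CC4)c3c2C(F)(F)F)CC(C)N1` differs from compound 2 on an aromatic carbon ortho to a fluoro group and ortho to a trifluoromethyl group: 3,5-dimethylpiperazin-1-yl in place of piperazin-1-yl on an aromatic carbon. Among the compounds with values here, the only measured step, a 20-fold higher number from compound 1 to compound 2 (1.30 log units; beyond the scatter), is large, but it is trifluoromethyl in place of methoxy and leaves the piperazin-1-yl unchanged. Within the data shown here, no measured step tests this change, so no direction is favoured and the range stays wide. Expected in this assay is a 1.3-fold lower number from compound 2 to compound 3 (0.10 log units; within the scatter), with no shift beyond the scatter. The estimate for compound 3 is 1300 ug/mL, range 400 ug/mL to 3500 ug/mL.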

Compound 3, half-maximal inhibitory concentration: > 500 ug/mL
Compound 3 ended at the assay's limit; the forecaster's own chance of this, stated with the estimate: 15%; the middle value lies beyond the limit too.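

Compound 3 gives > 500 ug/mL, a limit of the assay and not a number, so the step from compound 2 to compound 3 cannot be read. Going by these compounds, whether 3,5-dimethylpiperazin-1-yl in place of piperazin-1-yl shifts the number, and in which direction, stays open.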